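This account rests on a few compounds, and the source may have more. Where it says the series, first, only, none or still open, it means among the compounds named here.

Compound 1 `COCc1ncnc2c1ncn2[C@@H]1O[C@H](CO)[C@@H](O)[C@H]1O`: > 100000 nM
Compound 2 `CC(C)N(Cc1ncnc2c1ncn2[C@@H]1O[C@H](CO)[C@@H](O)[C@H]1O)C(C)C`: 18000 nM

In a functional assay on Huh-7 cells (Homo sapiens) for cytotoxicity, read by MTT assay, with a stated time of 3 days (on this read-out higher numbers stand for lower toxicity in this test and lower numbers for higher toxicity in this test), compound 1 gives > 100000 nM, which is a limit of the assay rather than a number. Compound 2 gives 18000 nM in this assay, the only number shown among the two values. Within the data shown here, the one measured step, an at least 5.5-fold lower number from compound 1 to compound 2 (0.74 log units; beyond the scatter), concerns the same saturated chain carbon bound to an aromatic carbon. Compound 3 `O=C1CCCN1Cc1ncnc2c1ncn2[C@@H]1O[C@H](CO)[C@@H](O)[C@H]1O` differs from compound 2 thus: 2-oxopyrrolidin-1-yl in place of diisopropylamino on a saturated chain carbon bound to an aromatic carbon. Among the measured compounds shown here, no measured step exchanges these two groups, so the direction is uncertain; a modest step back toward higher numbers is expected, a 2.8-fold higher number from compound 2 to compound 3 (0.44 log units; beyond the scatter), and compound 3 is estimated at 50000 nM with a range from 12000 nM to 200000 nM.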

Compound 3, half-maximal cytotoxic concentration: 45000 nM
Compound 3: the middle estimate sits 1.1-fold (0.05 log units) above what was measured; the measured number falls inside the stated range.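

In this assay, the saturated chain carbon bound to an aromatic carbon now carries a third group, and replacing diisopropylamino with 2-oxopyrrolidin-1-yl gives a 2.5-fold higher number from compound 2 to compound 3 (0.40 log units; beyond the scatter). Toxicity in this test is therefore not tied to diisopropylamino alone, since the change from methoxy to 2-oxopyrrolidin-1-yl still gives an at least 2.2-fold lower number from compound 1 to compound 3 (0.34 log units; beyond the scatter). The full size of that second step cannot be read, as compound 1 gives only a limit of the assay: the limit of > 100000 nM in this assay, at which 1 of the 3 values shown sits.

The compounds shown leave open how a simple primary amine or a carboxylic acid on this carbon would compare. They also leave open whether a longer chain between this carbon and the diisopropylamino group would change the number.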